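One Added Methyl on Compound 3

The compounds below may be only part of what the source reports. "The series", "measured", "known", "first", "only" and "open" are said of these compounds alone.

For the measured compounds named here, in an ADME assay on HepG2 cells (Homo sapiens) for cytotoxicity, read by MTT assay, with a stated time of 72 h (on this read-out lower numbers stand for higher toxicity in this test and higher numbers for lower toxicity in this test), compound 3 (`CC(O)C#Cc1cc(Cl)cn2c([N+](=O)[O-])c(CS(=O)(=O)c3ccccc3)nc12`) gives 44200 nM as the only actual number so far. Compound 1 (`O=[N+]([O-])c1c(CS(=O)(=O)c2ccccc2)nc2c(C#Cc3cccc(F)c3)cc(Cl)cn12`) shows > 3900 nM as a limit of the assay. Compound 2 (`O=[N+]([O-])c1c(CS(=O)(=O)c2ccccc2)nc2c(C#Cc3ccc(CO)cc3)cc(Cl)cn12`) shows > 15600 nM as a limit too. Compound 4 (`CC(C)(O)C#Cc1cc(Cl)cn2c([N+](=O)[O-])c(CS(=O)(=O)c3ccccc3)nc12`) carries one change: methyl in place of hydrogen on a saturated chain carbon bound to an oxygen on a saturated carbon, a saturated chain carbon and a triple-bonded carbon, turning 1-hydroxyethyl into 1-hydroxy-1-methylethyl. The measured steps a step that the limit leaves unreadable from compound 1 to compound 3 and a step that the limit leaves unreadable from compound 2 to compound 3 offer no size to build on, and neither adds a methyl. Resting on compound 3 at 44200 nM alone, no shift beyond the usual scatter is expected in this assay, in either direction. The expected change is a 1.1-fold lower number from compound 3 to compound 4 (0.02 log units; within the scatter) for now. For compound 4 the estimated value is 42000 nM (expected range 15000 nM to 110000 nM).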

Compound 4, half-maximal cytotoxic concentration: > 62500 nM
Compound 4 ended at the assay's limit (the forecaster's own chance of this, stated with the estimate: 30%); middle value at least 1.4-fold (0.17 log units) away from the limit.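

In this assay, for the compounds shown here, the methyl that turns 1-hydroxyethyl into 1-hydroxy-1-methylethyl gives an at least 1.4-fold higher number from compound 3 to compound 4 (0.15 log units; that floor lies within the scatter), the first step on this side chain with any readable size, and it shows no fall in the number. Going by these compounds, the result for compound 4 is a limit of the assay, so the full size of that step stays unknown. The steps to compound 4 from compound 1 and compound 2 cannot be read.

Still open, on these data alone, is how the number would respond to a longer chain, such as ethyl, in place of the added methyl, or to an amine in place of the hydroxyl.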